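The source may hold more compounds than are shown below. What is called first, only, known or untested is meant among the compounds shown, and "the series" means these compounds.

The measured compounds:
Compound 1, `Cc1ccc(S(=O)(=O)N[C@@H](CC(=O)NC(C)(C)C)C(=O)NCCNC(=O)Nc2ccccc2)cc1`. In an ADME assay on HepG2 cells (Homo sapiens) for cytotoxicity (on this read-out lower numbers stand for an effect already at smaller amounts and higher numbers for an effect only at larger amounts of compound), compound 1 gives > 11000 nM, which is a limit of the assay and not a number.
Compound 2, `Cc1ccc(S(=O)(=O)N[C@@H](CC(=O)NC(C)(C)C)C(=O)NCCNC(=O)c2cc(Cl)ccc2Cl)cc1`. In this assay compound 2 gives > 11000 nM, likewise a limit.

Compound 1 therefore stands only at a limit, and the two values shown both sit at the limit of > 11000 nM in this assay, at which 2 of the 2 values shown sit. For the measured compounds named here, the one measured step, a step that the two limits leave unreadable from compound 1 to compound 2, has no readable size, since it runs between two limits, and it changes a different part of the molecule from the one considered here. The unmeasured compound 3, `Cc1ccc(S(=O)(=O)N[C@@H](CC(=O)NC(C)(C)C)C(=O)NCCNC(=O)NCc2ccccc2)cc1`, differs from compound 1 by benzyl in place of phenyl on an amide-type nitrogen. Going by the values given here, no measured step bears on a change at this amide-type nitrogen, so no direction can be read from the data. With both measured compounds at the same limit, compound 3 is expected to stay at or beyond that limit, a step that the limit leaves unreadable from compound 1 to compound 3. Compound 3 is thus estimated at 15000 nM, in a range from 8000 nM to 40000 nM.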

Compound 3, half-maximal effective concentration: > 11000 nM
Compound 3 ended at the assay's limit (the forecaster's own chance of this, stated with the estimate: 85%); the middle value is on the limit's open side.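

No step from compound 1 or compound 2 to compound 3 can be read, because all three values are limits of the assay and not numbers: the limit of > 11000 nM in this assay, at which 3 of the 3 values shown sit.

The compounds shown leave open at what concentration any of the three would reach a half-maximal effect in this assay, and whether benzyl in place of phenyl alters it.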